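Methyl for methoxy on the aryl group of a pyrrolidine triol

The source may report more compounds than this note shows. Statements on the series, on what has been measured and on what is new or still open speak of the compounds shown alone.

Measured compounds:
compound 1, `OC[C@]1(c2ccc(F)cc2)NC[C@H](O)[C@H]1O`: 0%
compound 2, `COc1ccc([C@]2(CO)NC[C@@H](O)[C@@H]2O)cc1`: 2.7%
compound 3, `OC[C@]1(c2cccc(F)c2)NC[C@H](O)[C@H]1O`: 0%

Of the compounds shown here, three sharing one core have been tested in an assay on isolated protein for inhibition of tissue alpha-L-fucosidase (Bos taurus), tested at 1000 uM; on this read-out lower numbers stand for less inhibition and higher numbers for more inhibition at the one concentration tested (going by the name of the read-out). Compound 1 `OC[C@]1(c2ccc(F)cc2)NC[C@H](O)[C@H]1O` gives 0%, compound 2 `COc1ccc([C@]2(CO)NC[C@@H](O)[C@@H]2O)cc1` gives 2.7%, and compound 3 `OC[C@]1(c2cccc(F)c2)NC[C@H](O)[C@H]1O` gives 0%. Compound 2 has the highest of the three numbers, but the gaps to compound 1 and to compound 3 are both within the usual scatter of this assay, so the three compounds cannot be told apart on these data; all of them sit at the bottom of the scale.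

Compound 4 `Cc1ccc([C@]2(CO)NC[C@@H](O)[C@@H]2O)cc1` has not yet been measured in this assay. It differs from compound 2 in one place: methyl in place of methoxy on an aromatic carbon. Going by the values given here, no step between two measured compounds that differ in a single place is available, so there is nothing in the data to set the size of this change against.

Because compound 2 gives 2.7% and thus lies at the bottom of the scale, the change to compound 4 is expected to bring about no step beyond the scatter, and the step of a number 0.7 percentage points lower from compound 2 to compound 4 (within the scatter) is accordingly estimated to be small. Compound 4 is expected to give about 2% in this assay, with a range from 0% to 12%.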

Compound 4, a percentage reported as inhibition, at one concentration (the size of the read-out at that concentration, not a potency): 0%
Beside the measured number, compound 4's estimate is 2 percentage points above it, and the stated range covers the measured number.
By their numbers in this assay, from the lowest: compounds 1, 3, 4 and 2 (each within the scatter of the next).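

In this assay, going by these compounds alone, methyl in place of methoxy on an aromatic carbon, para to a group of 9 heavy atoms, gives a number 2.7 percentage points lower from compound 2 to compound 4 (within the scatter), the first step between two measured compounds that differ in one place. At this position, then, losing the methoxy group's oxygen and its one hydrogen-bond acceptor produces no difference that can be separated from the scatter, and both compounds stay at the bottom of the scale at the one concentration tested. No other measurement accompanies this step, so nothing here speaks to why the two compounds read alike.

With both numbers this close to the bottom of the scale, the step cannot show whether this position has any bearing on the inhibition of the enzyme, or whether the same exchange would matter on a compound with a clearly higher reading. As far as these compounds go, it also remains open whether an amine, a carboxylic acid or a longer alkoxy chain at this aromatic carbon would lift the number beyond the scatter.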